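One More Chloro on Compound 2

A few compounds are considered here, and "the series" means these few. Any claim that something is new, unique, unknown or untested is made for them only; others in the source may bear on it.

Two compounds have numbers in an ADME assay on liver (Mus musculus) for metabolic stability, read by LC-MS, using microsomes and NADPH (on this read-out lower numbers stand for a less stable compound and higher numbers for a more stable compound), so far. Compound 1 `CCCCN(Cc1ccc(OCCN2C(=O)CCC2=O)c(C)c1)C(CC(=O)O)c1ccc(Cl)cc1` gives 88% and compound 2 `COc1cc(CN(CC(C)C)C(CC(=O)O)c2ccc(Cl)cc2)ccc1OCCN1C(=O)CCC1=O` gives 69% as the lower of the two, a gap beyond the usual scatter. The next compound, compound 3 `COc1cc(CN(CC(C)C)C(CC(=O)O)c2ccc(Cl)cc2Cl)ccc1OCCN1C(=O)CCC1=O`, departs from compound 2 by a single change, (chloro in place of hydrogen on an aromatic carbon), which is chloro in place of hydrogen on an aromatic carbon, ortho to a large group and meta to a chloro group. It turns 4-chlorophenyl to 2,4-dichlorophenyl. For the measured compounds named here, no two measured compounds differ in only one place, so the data offer no direct guide to this change. The expected step of a number 1 percentage points lower from compound 2 to compound 3 (within the scatter) is therefore small, within the scatter, with no direction favoured. Compound 3 is estimated at 68% in this assay with a wide expected range (48% to 86%).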

Compound 3, percent of the compound remaining: 67%
Estimate against measurement, compound 3: 1 percentage points above, and the stated range covers the measured number.
By their numbers in this assay, from the lowest: compounds 3 and 2 (each within the scatter of the next); then compound 1.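

With this pair the set gains its first comparison in one place. In this assay the chloro in place of hydrogen on an aromatic carbon, ortho to a large group and meta to a chloro group, gives a number 2 percentage points lower from compound 2 to compound 3 (within the scatter) and so turning 4-chlorophenyl to 2,4-dichlorophenyl does not separate the two compounds on this read-out. Nothing measured here bears on why this step is so small.

Whether a fluoro group or a nitrile at this same place would also stay within the scatter remains open, as chloro is the only group shown there apart from hydrogen. Also open, on these data alone, is whether the same chloro would give a step of like size on compound 1, which carries a butyl chain and a methyl group.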